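The source may report more compounds than this note shows. Statements on the series, on what has been measured and on what is new or still open speak of the compounds shown alone.

Working notes on the series. Compound 3 `CCCCCCCCCCCCCCCCCCC1(C(=O)OC)CO1` belongs with compound 1 `CCCCC/C=C/CCCCCCCCCC1(C(=O)OC)CO1` and compound 2 `CCCCCCCCCCCCCCCCCCCCCCC1(C(=O)OC)CO1`, all three sharing the same core and differing only along the chain. In a functional assay on the whole organism with Rattus norvegicus as the target, in the glucose tolerance test (a lower number here means that less compound is needed, a higher number that more compound is needed for the effect), compound 1 gives 10 mg/kg, compound 2 gives 10 mg/kg, and compound 3 gives 10 mg/kg; compound 3 thus stands level with both at the digits shown, within the usual scatter in each case. Among the measured compounds shown here, the one step measured along the chain, no change at the digits printed from compound 2 to compound 3 (within the scatter), shows that trimming the chain end leaves this assay unmoved.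

Compound 4 `COC(=O)C1(CCCCCCCCCCc2ccccc2)CO1` differs from compound 3 in one place: phenyl in place of octyl on a saturated chain carbon, ten or more bonds along the chain from a saturated ring carbon. For the measured compounds named here, no measured step exchanges a chain segment for an aromatic ring, so the only guidance is the chain-shortening step, which was flat. On that basis the step of no change at the digits printed from compound 3 to compound 4 (within the scatter) is expected to stay within the scatter, with no direction favoured. For compound 4 the estimate in this assay is 10 mg/kg, with a range from 5 mg/kg to 30 mg/kg.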

Compound 4, minimum effective dose: 10 mg/kg
Beside the measured number, compound 4's estimate shows no gap at the digits printed; the range from low to high includes it.
By their numbers in this assay, from the lowest: compounds 1, 2, 3 and 4 (each within the scatter of the next).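

In this assay, among the compounds shown here, the earlier compounds varied only the open chain, whereas phenyl in place of octyl on a saturated chain carbon, ten or more bonds along the chain from a saturated ring carbon, gives no change at the digits printed from compound 3 to compound 4 (within the scatter), so this position carries a six-membered aromatic ring of carbon only with no shift beyond the scatter. Benzyl in place of hept-1-en-1-yl, nine bonds along the chain from a saturated ring carbon, likewise gives no change at the digits printed from compound 1 to compound 4 (within the scatter), so the aromatic chain end and the unsaturated one read alike here. Nothing available accounts for this flat result.

On these data alone, whether an amine or a carboxylic acid at the chain end, or a much shorter chain, would move the minimum effective dose remains open. As far as these compounds go, the methyl ester and the shared core stay the same throughout these compounds, so their contribution also remains open.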